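The source may report more compounds than this note shows. Statements on the series, on what has been measured and on what is new or still open speak of the compounds shown alone.

Compound 1, `Cc1cccc(NC(=O)N[C@@H](C)c2ccccc2)c1`, and compound 2, `CCOC(=O)c1cccc(NC(=O)N[C@H](C)c2ccccc2)c1`, share a urea core joined to a methyl-bearing stereocentre. In an ADME assay on the whole organism with Oryza sativa as the target, tested at 1 uM (on this read-out higher numbers stand for a weaker effect at the one concentration tested and lower numbers for a stronger effect), compound 1 gives 100%, and in this assay compound 2 gives 94%. Within the data shown here, of the two numbers, the one for compound 2 is the smaller on paper, yet the gap to compound 1 falls within the scatter of repeated measurements, so the two cannot be told apart. The next compound, compound 3, `CCOC(=O)c1cccc(NC(=O)N[C@@H](C)c2ccccc2)c1`, is the mirror image of compound 2: the two compounds have the same atoms and bonds and differ only in configuration as drawn: 1 of 1 stereo elements differ; a stereocentre at a saturated chain carbon is drawn R in compound 2 and S in compound 3. Among the measured compounds shown here, no pair of measured compounds differing in one place is available here, so nothing within this set sizes such a step. With both measured compounds sitting near the top of the scale in this assay, the step from compound 2 to compound 3 is expected to be a number 2 percentage points higher from compound 2 to compound 3 (within the scatter), none beyond the scatter in either direction. Compound 3 is therefore estimated at 96% in this assay, with a range from 84% to 106%.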

Compound 3, a percentage reported as activity, at one concentration (the size of the read-out at that concentration, not a potency): 99%
For compound 3 the middle estimate is 3 percentage points below the measured one, within the range that was stated.
By their numbers in this assay, from the lowest: compounds 2, 3 and 1 (each within the scatter of the next).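

In this assay the read-out gives a number 5 percentage points higher from compound 2 to compound 3 (within the scatter), so inverting the stereocentre at the saturated chain carbon leaves no effect that can be told from the scatter, and the comparison rests on configuration alone: the fact that compounds 2 and 3 differ only in the configuration as drawn With the configuration drawn the same, ethoxycarbonyl in place of methyl on an aromatic carbon gives a number 1 percentage points lower from compound 1 to compound 3 (within the scatter), so this exchange cannot be told from the scatter either. Among these compounds, these are the first comparisons in the set that change one place at a time, and neither separates its two compounds.

As far as these compounds go, what stays open is whether any group on that aromatic carbon can move this read-out beyond the scatter, for instance a carboxylic acid or an amine. Also open, from the compounds shown here alone, is whether the configuration would matter with such a group in place.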